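The source may hold more compounds than are shown below. What is called first, only, known or untested is meant among the compounds shown, and "the series" means these compounds.

Measured compounds, in a functional assay on OCI-Ly3 cells (Homo sapiens) for inhibition, read by CellTiter-Glo, with stated times of 48 h and 96 h; on this read-out higher numbers stand for weaker inhibition of growth and lower numbers for stronger inhibition of growth:
- compound 1 `CC(C)[C@H](NC(=O)OCc1ccccc1)C(=O)N1CCC[C@H]1C(=O)N(C)[C@@H](CCCNC(=N)N)C(=O)CF`: "not determined" (no result reported)
- compound 2 `CC(C)[C@H](NC(=O)c1ccccc1Br)C(=O)N1CCC[C@H]1C(=O)N[C@@H](CCCNC(=N)N)C(=O)CF`: 4240 nM

The record for this series is thin. Among the measured compounds shown here, compound 1 has no result in this assay, so compound 2, at 4240 nM, supplies the only number. For the measured compounds named here, it therefore cannot be ranked against anything, and no measured step between two compounds is available as a guide.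

The next compound is compound 3 `CC(C)[C@H](NC(=O)c1ccc(Cl)cc1)C(=O)N1CCC[C@H]1C(=O)N[C@@H](CCCNC(=N)N)C(=O)CF`, which keeps the core of compound 2 and changes one group: 4-chlorophenyl in place of 2-bromophenyl on a carbonyl carbon. In words, 4-chlorophenyl stands in place of 2-bromophenyl on a carbonyl carbon. Neither group has been tested alone, and the data offer no sign of how growth inhibition responds to a change at this place.

With no evidence for a direction, the expectation stays anchored on compound 2 at 4240 nM, with no shift beyond the usual scatter. The expected change is a 1.2-fold lower number from compound 2 to compound 3 (0.08 log units; within the scatter). For compound 3 the estimated value is 3500 nM, with an expected range of 1200 nM to 10000 nM.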

Compound 3, concentration for 50% growth inhibition: 1240 nM
Compound 3: middle estimate off by 2.8-fold (0.45 log units), on the high side, within the range that was stated.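

In this assay, 4-chlorophenyl in place of 2-bromophenyl on a carbonyl carbon whose other neighbour is an amide-type nitrogen gives a 3.4-fold lower number from compound 2 to compound 3 (0.53 log units; beyond the scatter), a modest step but the first sign that growth inhibition responds to a change at this place. The response appears even though the two groups match in heavy-atom count, each has one six-membered aromatic ring of carbon only, and neither has hydrogen-bond donors, hydrogen-bond acceptors or a net charge. The single step changes both the halogen and where it sits on the ring, so the two changes cannot be separated, and no measurement shown here accounts for the difference.

Still open, going by these compounds, is how 4-bromophenyl or 2-chlorophenyl would read on the same carbonyl carbon, as either group would separate the identity of the halogen from its placement. On these data alone, it is also open whether plain phenyl would keep the lower number of compound 3, and whether 4-methoxyphenyl or 4-(trifluoromethyl)phenyl would lower it further or raise it again.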